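This account rests on a few compounds, and the source may have more. Where it says the series, first, only, none or still open, it means among the compounds named here.

In a functional assay on A549 cells (Homo sapiens) for antiproliferative activity, read by MTT assay, with a stated time of 72 h (a lower number here means a stronger inhibitor, a higher number a weaker inhibitor), compound 1 (`COc1ncc(-c2ccc3c(c2)NC(=O)CO3)cc1NS(=O)(=O)c1ccc(F)cc1`) gives 8070 nM, compound 2 (`CC(C)N1C(=O)COc2ccc(-c3cnc(Cl)c(NS(=O)(=O)c4ccc(F)cc4)c3)cc21`) gives 5100 nM, and compound 3 (`O=C1COc2ccc(-c3cnc(Cl)c(NS(=O)(=O)c4ccc(F)cc4)c3)cc2N1c1ccc(F)cc1`) gives 22300 nM. Compound 3 thus has the highest number of the three and is the weakest inhibitor here, with its gaps to both others beyond the scatter.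

Compound 4 (`O=C1COc2ccc(-c3cnc(Cl)c(NS(=O)(=O)c4ccc(F)cc4)c3)cc2N1`), not yet measured, differs from compound 3 at one place: hydrogen in place of 4-fluorophenyl on an amide-type nitrogen in a ring. In words, hydrogen stands in place of 4-fluorophenyl on an amide-type nitrogen in a ring.

Going by the values given here, only one measured step involves a change at this nitrogen. With 4-fluorophenyl in place of isopropyl, the data show a 4.4-fold higher number from compound 2 to compound 3 (0.64 log units; beyond the scatter), a modest step beyond the scatter. Removing the 4-fluorophenyl might reverse a step of that kind, so a lower number of similar modest size is expected. Among the compounds with values here, this is only an expectation, as no measured pair compares hydrogen with either group while all else stays the same. Compound 1 also carries hydrogen on that nitrogen but differs elsewhere, so its 8070 nM is only a rough guide.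

The expected change is a 3.0-fold lower number from compound 3 to compound 4 (0.47 log units; beyond the scatter). The estimated value for compound 4 is 7500 nM, with an expected range of 2800 nM to 20000 nM.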

Compound 4, half-maximal inhibitory concentration: > 40000 nM
Compound 4: only a limit was reported; the forecaster's own chance of this, stated with the estimate: 3%; middle value at least 5.3-fold (0.72 log units) from the limit.
By their numbers in this assay, from the lowest: compounds 2 and 1 (each within the scatter of the next); then compound 3. At a limit, above all of these: compound 4.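

In this assay compound 4 gives only a limit of the assay, not a number: the limit of > 40000 nM in this assay, at which 1 of the 4 values shown sits. Going by these compounds alone, this shows that a hydrogen on this ring nitrogen is no gain over isopropyl, with an at least 7.8-fold higher number from compound 2 to compound 4 (0.89 log units; beyond the scatter), and that the group on this nitrogen matters in a way the single earlier step could not show: isopropyl is clearly better than hydrogen, even though 4-fluorophenyl had given a higher number than isopropyl. On these data alone, with hydrogen on the nitrogen, the aromatic carbon matters too, as chloro in place of methoxy brings an at least 4.9-fold higher number from compound 1 to compound 4 (0.69 log units; beyond the scatter), while the comparison with 4-fluorophenyl gives only an at least 1.7-fold higher number from compound 3 to compound 4 (0.25 log units; that floor lies within the scatter), so the true size of that step stays unknown.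

The compounds shown leave open how a methyl, an ethyl or a longer chain ending in an amine on this nitrogen would compare with isopropyl. They also leave open whether chloro in place of methoxy would bring a step of similar size with isopropyl on the nitrogen instead of hydrogen.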